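A few compounds are considered here, and "the series" means these few. Any claim that something is new, unique, unknown or untested is made for them only; others in the source may bear on it.

Of the compounds shown here, three sharing one core have been tested in a functional assay on HeLa cells (Homo sapiens) for cytotoxicity, read by MTT assay; on this read-out lower numbers stand for stronger inhibition and higher numbers for weaker inhibition. Compound 2 `COC(=O)C[C@H]1C[C@@H](O)[C@@H](C)[C@@H](c2ccc(OC)cc2)N1` gives 11500 nM, the higher of the two numbers available, while compound 3 `COC(=O)C[C@H]1C[C@H](O)[C@@H](C)[C@@H](c2ccc(OC)cc2)N1` gives 5300 nM. Among the measured compounds shown here, the only measured step is a 2.2-fold lower number from compound 2 to compound 3 (0.34 log units; beyond the scatter), and it goes with the fact that compounds 2 and 3 differ only in the configuration as drawn. That step is a change of configuration, so it offers little guide to a change of group.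

Compound 4 `COC(=O)C[C@H]1C[C@@H](O)[C@@H](C)[C@@H](c2ccc(F)cc2)N1` keeps the configuration of compound 2 but has fluoro in place of methoxy on an aromatic carbon. For the measured compounds named here, no pair with two numbers tests a swap at that carbon. The nearest hint comes from compound 1 `COC(=O)C[C@H]1C[C@@H](O)[C@@H](C)[C@@H](c2ccc(C(C)C)cc2)N1`, which carries another group on the same aromatic carbon and is reported as "not active" (no number reported). So a different group there may cost activity, but the size of that loss is unknown. In this assay, going by the values given here, the expectation is therefore no step clearly beyond the scatter, with a slight lean towards a higher number and a real chance of no number at all. The expected change is a 1.3-fold higher number from compound 2 to compound 4 (0.12 log units; within the scatter). For compound 4 the estimated value is 15000 nM, with an expected range from 6000 nM to 40000 nM.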

Compound 4, half-maximal inhibitory concentration: 19800 nM
For compound 4 the middle estimate is 1.3-fold (0.12 log units) below the measured one, within the range that was stated.
By their numbers in this assay, from the lowest: compound 3; then compounds 2 and 4 (each within the scatter of the next).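

In this assay, putting fluoro in place of methoxy on the aromatic carbon, para to a large group, gives a 1.7-fold higher number from compound 2 to compound 4 (0.24 log units; within the scatter), so this first pair with two numbers for a swap at this carbon cannot be told apart. Methoxy counts as a hydrogen-bond acceptor and fluoro does not, yet that difference in the count comes with no step beyond the scatter. Compound 1, with isopropyl on the same carbon, reads "not active" (no number reported), whereas compound 4 keeps a measurable number, so a different group at this carbon does not always leave the compound without a number, and nothing measured here explains either outcome.

Open still is whether fluoro would respond to the change of configuration as methoxy does in a 2.2-fold lower number from compound 2 to compound 3 (0.34 log units; beyond the scatter), since only the methoxy pair shows that step. Also open, from the compounds shown here alone, is how an amine, a carboxylic acid or a nitrile on this aromatic carbon would read, and whether any such group would move the number beyond the scatter in either direction.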